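Removing the bromoacrylamide from a thiazolidinedione anilide

The source may report more compounds than this note shows. Statements on the series, on what has been measured and on what is new or still open speak of the compounds shown alone.

Three compounds here share one core and are measured in a functional assay on CCRF-CEM cells (Homo sapiens) for cytotoxicity, read by cell counting, with a stated time of 3 days; a lower number here means a stronger inhibitor, a higher number a weaker inhibitor. Compound 1, `C=C(Br)C(=O)Nc1ccc(/C=C2\SC(=O)N(Cc3cccc(F)c3)C2=O)cc1`, gives 3200 nM. Compound 2, `C=C(Br)C(=O)Nc1ccc(/C=C2\SC(=O)N(Cc3cccc(Cl)c3)C2=O)cc1`, gives 3700 nM, and compound 3, `C=C(Br)C(=O)Nc1ccc(/C=C2\SC(=O)N(Cc3ccc(C)cc3)C2=O)cc1`, gives 3700 nM. Compound 1 carries the lowest of the three numbers, but the steps of a 1.2-fold higher number from compound 1 to compound 2 (0.06 log units; within the scatter) and a 1.2-fold higher number from compound 1 to compound 3 (0.06 log units; within the scatter) are both within the scatter, as is no change at the digits printed from compound 2 to compound 3 (within the scatter), so the three values are best read as one level rather than an order.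

Compound 4, `Nc1ccc(/C=C2\SC(=O)N(Cc3cccc(F)c3)C2=O)cc1`, has not yet been measured. It differs from compound 1 by hydrogen in place of (1-bromoethenyl)carbonyl on a nitrogen on an aromatic ring. Within the data shown here, all three measured steps change the group on the saturated chain carbon bound to the amide-type nitrogen in the ring; none of them touches the nitrogen on the aromatic ring where compound 4 differs, so no measured step bears directly on this change. The measured steps show only that the series tolerates small changes elsewhere without movement beyond the scatter.

With nothing measured to anchor the step, the estimate for compound 4 is 15000 nM, with a range from 4000 nM to 60000 nM. This estimate corresponds to an expected step of a 4.7-fold higher number from compound 1 to compound 4 (0.67 log units; beyond the scatter), in the direction of a weaker inhibitor.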

Compound 4, half-maximal inhibitory concentration: 116000 nM
For compound 4 the middle estimate is 7.7-fold (0.89 log units) below the measured one; the measured number lies above the stated range.
By their numbers in this assay, from the lowest: compounds 1, 2 and 3 (each within the scatter of the next); then compound 4.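

Taking the (1-bromoethenyl)carbonyl off the nitrogen on the aromatic ring and leaving a bare amino group gives a 36-fold higher number from compound 1 to compound 4 (1.56 log units; beyond the scatter) in this assay, the first step in this set that goes beyond the scatter. This nitrogen is therefore a place where the number in this assay responds strongly, whereas the changes among compounds 1, 2 and 3, all made at the other end of the shared core, moved it by no more than the scatter. Nothing measured here explains why the number rises so far at this position.

The bromine, the carbon-carbon double bond and the carbonyl all leave together in this one step, so the compounds shown cannot say which of them matters. A plain acetyl group or a propenoyl group without the bromine on the same nitrogen would divide the step into smaller parts, and the bare amino group paired with the 3-chlorophenyl or 4-methylphenyl of compounds 2 and 3 would test whether it holds beyond the 3-fluorophenyl of compound 1.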